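The source may report more compounds than this note shows. Statements on the series, on what has been measured and on what is new or still open speak of the compounds shown alone.

Compound 1 `CCCCCCCCOC(=O)C(O)Cn1cnc2c(N)ncnc21` carries an octyl chain on an oxygen next to a carbonyl group. Going by the values given here, in a functional assay on PRK cells (Oryctolagus cuniculus) for cytotoxicity (a higher number here means that more compound is tolerated, a lower number that less compound is tolerated), compound 1 gives 100 ug/mL, the only outright number among the three measured compounds. Compound 2 `CC(C)COC(=O)C(O)Cn1cnc2c(N)ncnc21` is a shorter, branched relative. In this assay compound 2 reaches only a limit, > 400 ug/mL. Compound 3 `CC(C)(C)OC(=O)C(O)Cn1cnc2c(N)ncnc21` is branched still more tightly. For compound 3 this assay again records a limit, > 400 ug/mL. Both shortenings therefore read as an at least 4.0-fold higher number from compound 1 to compound 2 (0.60 log units; beyond the scatter) and an at least 4.0-fold higher number from compound 1 to compound 3 (0.60 log units; beyond the scatter), while the step between them, a step that the two limits leave unreadable from compound 2 to compound 3, cannot be sized because of the limit of > 400 ug/mL in this assay, at which 2 of the 3 values shown sit.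

Compound 4 `CCOC(=O)C(O)Cn1cnc2c(N)ncnc21` continues in the same direction: hydrogen in place of hexyl on a saturated chain carbon, two bonds along the chain from an oxygen next to a carbonyl group. Both measured shortenings of this chain lowered the cytotoxicity at least modestly, so for compound 4 a rise of similar or larger size is expected in this assay, estimated as a 4.0-fold higher number from compound 1 to compound 4 (0.60 log units; beyond the scatter). Compound 4 is thus expected to come out near 400 ug/mL, within 200 ug/mL to 800 ug/mL, most likely again only as a limit.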

Compound 4, minimum cytotoxic concentration: > 400 ug/mL
Compound 4: only a limit was reported (the forecaster's own chance of this, stated with the estimate: 70%); the middle value lies on the limit itself.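

In this assay, putting hydrogen in place of hexyl at this carbon, two bonds along the chain from an oxygen next to a carbonyl group, gives an at least 4.0-fold higher number from compound 1 to compound 4 (0.60 log units; beyond the scatter). This shows that the move away from the octyl chain of compound 1 does not depend on branching, since the straight ethyl chain of compound 4 shares it with the branched chains of compound 2 and compound 3. Compound 4 is reported only as a limit, > 400 ug/mL, and the steps among compound 2, compound 3 and compound 4 cannot be read because all three stop at the same limit: the limit of > 400 ug/mL in this assay, at which 3 of the 4 values shown sit.

Still open, on these data alone, is where between ethyl and octyl the tolerated amount begins to fall, for example with a butyl or hexyl chain. Also open, as far as these compounds go, is whether an octyl chain ending in an amine or a carboxylic acid would behave like that of compound 1.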